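A few compounds are considered here, and "the series" means these few. Any claim that something is new, unique, unknown or untested is made for them only; others in the source may bear on it.

Measured compounds:
Compound 1 `CCCCCc1ccc(-c2cn(-c3cccc(C(=O)/C=C/c4ccc(O)c(OC)c4)c3)nn2)cc1`: 5780 nM
Compound 2 `COc1cc(/C=C/C(=O)c2cccc(-n3cc(-c4ccccc4C(F)(F)F)nn3)c2)ccc1O`: 5070 nM

In a functional assay on RAW264.7 cells (Mus musculus) for inhibition, with a stated time of 4 days (a lower number here means a stronger inhibitor, a higher number a weaker inhibitor), compound 1 gives 5780 nM and compound 2 gives 5070 nM. Compound 2 holds the lower of the two numbers, but the step of a 1.1-fold lower number from compound 1 to compound 2 (0.06 log units; within the scatter) means the two compounds cannot be set apart on these figures.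

The next compound is compound 3 `COc1cc(/C=C/C(=O)c2cccc(-n3cc(-c4cc(F)cc(F)c4)nn3)c2)ccc1O`. It differs from compound 2 in one place: 3,5-difluorophenyl in place of 2-(trifluoromethyl)phenyl on an aromatic carbon.

For the measured compounds named here, only one measured step bears on this change, and it is the same kind of exchange of the aryl group on the five-membered aromatic ring: a 1.1-fold lower number from compound 1 to compound 2 (0.06 log units; within the scatter). That exchange, from a 4-pentylphenyl to a 2-(trifluoromethyl)phenyl, left the number essentially unchanged. Nothing measured here separates one substituted phenyl from another at this position, so no step beyond the scatter is expected in this assay for compound 3.

Compound 3 is therefore estimated at 5000 nM in this assay, within a range of 2000 nM to 12500 nM. This estimate corresponds to an expected step of a 1.0-fold lower number from compound 2 to compound 3 (0.01 log units; within the scatter).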

Compound 3, half-maximal inhibitory concentration: 22800 nM
Estimate against measurement, compound 3: 4.6-fold (0.66 log units) below; the measured number lies above the stated range.
By their numbers in this assay, from the lowest: compounds 2 and 1 (each within the scatter of the next); then compound 3.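

In this assay the aryl group on this five-membered aromatic ring proves not to be freely exchangeable: the step of a 4.5-fold higher number from compound 2 to compound 3 (0.65 log units; beyond the scatter) and the step of a 3.9-fold higher number from compound 1 to compound 3 (0.60 log units; beyond the scatter) both lie beyond the scatter, while the exchange between 4-pentylphenyl and 2-(trifluoromethyl)phenyl had produced no readable change. The position therefore responds to the choice of substituted phenyl, though both steps are modest, and the 3,5-difluorophenyl gives the weakest inhibitor of the three in this assay. Nothing available accounts for why this group stands apart from the other two.

The three compounds leave open whether the loss follows from the two fluorines themselves, from where they sit on the phenyl ring, or from the absence of a larger group such as trifluoromethyl or pentyl. From the compounds shown here alone, it also remains open whether an unsubstituted phenyl, a chlorophenyl, or a phenyl carrying an amine or a carboxylic acid would stay level with compound 1 and compound 2 or fall back towards compound 3.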